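Replacing 1H-pyrrol-1-yl with dimethylamino in compound 1

A few compounds are considered here, and "the series" means these few. Any claim that something is new, unique, unknown or untested is made for them only; others in the source may bear on it.

- Compound 1 `Cc1nn(C)c(-n2cccc2)c1/C=N/OCc1ccc(C(=O)OC(C)(C)C)cc1`: 2.67 ug/mL
- Compound 2 `Cc1nn(C)c(-n2ccc3ccccc32)c1/C=N/OCc1ccc(C(=O)OC(C)(C)C)cc1`: 1.61 ug/mL
- Compound 3 `Cc1nn(C)c(N2CCCC2)c1/C=N/OCc1ccc(C(=O)OC(C)(C)C)cc1`: 0.12 ug/mL
- Compound 4 `Cc1nn(C)c(N(C)C)c1/C=N/OCc1ccc(C(=O)OC(C)(C)C)cc1`: not yet measured

In a functional assay on XF498 cells (Homo sapiens) for cytotoxicity (a higher number here means a weaker inhibitor, a lower number a stronger inhibitor), compound 1 has the highest number of the three, but its nearest neighbour shows only a 1.7-fold lower number from compound 1 to compound 2 (0.22 log units; within the scatter). Its furthest neighbour shows a 22-fold lower number from compound 1 to compound 3 (1.35 log units; beyond the scatter).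

Compound 4 changes the same place on the shared core: dimethylamino in place of 1H-pyrrol-1-yl on an aromatic carbon. The closest guide is the pyrrolidin-1-yl group, which also gave a 13-fold lower number from compound 2 to compound 3 (1.13 log units; beyond the scatter). Dimethylamino, like pyrrolidin-1-yl, is not an aromatic group, but this comparison rests on compound 3 alone. A clear fall in this assay is therefore expected, perhaps smaller than that seen for compound 3.

The expected change is an 8.9-fold lower number from compound 1 to compound 4 (0.95 log units; beyond the scatter).

Compound 4 is estimated at 0.3 ug/mL, with an expected range of 0.08 ug/mL to 1.2 ug/mL.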

Compound 4, half-maximal inhibitory concentration: 3.87 ug/mL
The estimate for compound 4 lay 13-fold (1.11 log units) below the measured number; measured number above the stated range.
By their numbers in this assay, from the lowest: compound 3; then compounds 2, 1 and 4 (each within the scatter of the next, the first and the last beyond it).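

In this assay, removing the aromatic ring at this position is not enough to give a low number: dimethylamino in place of 1H-pyrrol-1-yl gives only a step within the scatter (a 1.4-fold higher number from compound 1 to compound 4 (0.16 log units; within the scatter)). The low number instead goes with pyrrolidin-1-yl specifically, as opening that ring into dimethylamino gives a large rise (a 32-fold higher number from compound 3 to compound 4 (1.51 log units; beyond the scatter)). Against 1H-indol-1-yl, dimethylamino gives a modest rise (a 2.4-fold higher number from compound 2 to compound 4 (0.38 log units; beyond the scatter)).

On these data alone, whether other ring amines, such as piperidin-1-yl or morpholin-4-yl, keep the low number remains open, as does the effect of a diethylamino group. No available measurement explains the gap between pyrrolidin-1-yl and dimethylamino.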